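Sulfamoylphenyl Variant Tested Against Endothelial Cell Growth

The compounds below may be only part of what the source reports. "The series", "measured", "known", "first", "only" and "open" are said of these compounds alone.

Three compounds share one core and differ only in the aryl group on an aromatic nitrogen. Compound 1 `Cc1ccccc1-n1nncc1CN1C(=O)C2(C(C#N)=C(N)Oc3c2c2nc4ccccc4nc2c2ccccc32)c2ccccc21` carries a 2-methylphenyl there. In an ADME assay on HUVEC cells (Homo sapiens) for antiproliferative activity, read by MTT assay, with a stated time of 48 h (a higher number here means a weaker inhibitor, a lower number a stronger inhibitor), compound 1 gives > 50000 nM, which is a limit of the assay and not a number. Compound 2 `N#CC1=C(N)Oc2c(c3nc4ccccc4nc3c3ccccc23)C12C(=O)N(Cc1cnnn1-c1ccccc1Cl)c1ccccc12` carries a 2-chlorophenyl instead. In this assay compound 2 likewise reaches only a limit, > 50000 nM. Compound 3 `N#CC1=C(N)Oc2c(c3nc4ccccc4nc3c3ccccc23)C12C(=O)N(Cc1cnnn1-c1ccc(Br)cc1)c1ccccc12` carries a 4-bromophenyl. In this assay compound 3 gives > 50000 nM, again a limit. Compound 2 thus stands at the same limit as both neighbours, and all three values sit at the limit (the limit of > 50000 nM in this assay, at which 3 of the 3 values shown sit).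

Compound 4 `N#CC1=C(N)Oc2c(c3nc4ccccc4nc3c3ccccc23)C12C(=O)N(Cc1cnnn1-c1cccc(S(N)(=O)=O)c1)c1ccccc12` differs from compound 2 in one place: 3-sulfamoylphenyl in place of 2-chlorophenyl on an aromatic nitrogen. Going by the values given here, the measured steps that bear on this exchange of one aryl group on the same nitrogen are a step that the two limits leave unreadable from compound 1 to compound 2 and a step that the two limits leave unreadable from compound 2 to compound 3, and the third, a step that the two limits leave unreadable from compound 1 to compound 3, is equally unreadable, so no measured step gives a direction or a size. Compound 4 is therefore expected to show a step that the limit leaves unreadable from compound 2 to compound 4 that stays within the scatter. For compound 4 the estimate is 70000 nM, with a range from 20000 nM to 250000 nM, and most likely only a limit will again be reported.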

Compound 4, half-maximal inhibitory concentration: 38600 nM
The estimate for compound 4 lay 1.8-fold (0.26 log units) above the measured number; the measured number falls inside the stated range.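

In this assay, going by these compounds alone, compound 4 is the only one of the four compounds to give a number and not a limit, so the aryl group on this aromatic nitrogen is no longer a place where every exchange ends in the same unreadable result. The exchange to 3-sulfamoylphenyl gives an at least 1.2-fold lower number from compound 2 to compound 4 (0.11 log units; that floor lies within the scatter) and an at least 1.2-fold lower number from compound 3 to compound 4 (0.11 log units; that floor lies within the scatter) and an at least 1.2-fold lower number from compound 1 to compound 4 (0.11 log units; that floor lies within the scatter) in this series, and each of these floors still falls short of a step that could be called real. From the compounds shown here alone, the true size of these steps stays unknown, and the steps among compound 1, compound 2 and compound 3 cannot be read at all, since those compounds give no number: the limit of > 50000 nM in this assay, at which 3 of the 4 values shown sit.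

The compounds shown leave open whether compound 4 truly stands apart from its three neighbours by more than the scatter. They also leave open whether a number would appear with a carboxylic acid or an amine in place of the sulfamoyl group on that phenyl ring, or with 4-sulfamoylphenyl on the same nitrogen.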